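The compounds below may be only part of what the source reports. "The series", "measured", "known", "first", "only" and "open" are said of these compounds alone.

Measured in a functional assay on MDA-MB-231 cells (Homo sapiens) for cytotoxicity, read by MTT assay, with a stated time of 48 h; a lower number here means a stronger inhibitor, a higher number a weaker inhibitor:
Compound 1 `CC(=O)Nc1ccc(NC(=O)NCCCCC(c2ccc(F)cc2)c2ccc(F)cc2)cc1`: > 20000 nM, a limit of the assay
Compound 2 `O=C(NCCCCC(c1ccc(F)cc1)c1ccc(F)cc1)Nc1cccc(C(F)(F)F)c1`: 3380 nM
Compound 3 `CC(=O)Nc1cc(NC(=O)NCCCCC(c2ccc(F)cc2)c2ccc(F)cc2)ccc1Cl`: 9120 nM

Compound 3 stands highest of the two actual numbers. The gap to its nearest neighbour is a 2.7-fold higher number from compound 2 to compound 3 (0.43 log units; beyond the scatter). Next comes compound 4 `O=C(NCCCCC(c1ccc(F)cc1)c1ccc(F)cc1)Nc1ccc([N+](=O)[O-])c(Cl)c1`, with 3-chloro-4-nitrophenyl in place of 3-acetamido-4-chlorophenyl on an amide-type nitrogen. Like compound 2, it carries no acetamido group. Exchanges of that kind are the nearest guide, and the measured exchange of an acetamido-bearing ring for one without it gave an at least 5.9-fold lower number from compound 1 to compound 2 (0.77 log units; beyond the scatter). Compound 2 also sits below compound 3 by the gap above. A modest fall in this assay is therefore expected, an estimated 2.3-fold lower number from compound 3 to compound 4 (0.36 log units; beyond the scatter). Compound 4 is estimated at 4000 nM, with an expected range from 1500 nM to 10000 nM.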

Compound 4, half-maximal inhibitory concentration: 3470 nM
Compound 4: the middle estimate sits 1.2-fold (0.06 log units) above what was measured; low and high end bracket the measured number.
By their numbers in this assay, from the lowest: compounds 2 and 4 (each within the scatter of the next); then compound 3. At a limit, above all of these: compound 1.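

With chlorine on the ring in both compounds, 3-chloro-4-nitrophenyl in place of 3-acetamido-4-chlorophenyl gives a 2.6-fold lower number from compound 3 to compound 4 (0.42 log units; beyond the scatter), so the drop seen earlier for a ring without an acetamido group also appears with chlorine present. A second ring without that group now matches the first, a 1.0-fold higher number from compound 2 to compound 4 (0.01 log units; within the scatter), and the two rings cannot be told apart here. The comparison with compound 1 gives only a bound, an at least 5.7-fold lower number from compound 1 to compound 4 (0.76 log units; beyond the scatter), as compound 1 stands at a limit: the limit of > 20000 nM in this assay, at which 1 of the 4 values shown sits.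

From the compounds shown here alone, whether an amine or a carboxylic acid on this ring would give a lower number than compound 2 and compound 4 remains open.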